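A few compounds are considered here, and "the series" means these few. Any claim that something is new, unique, unknown or untested is made for them only; others in the source may bear on it.

Working notes on the series. Compound 1, `CCc1cc(C(=O)N2CC=CC2)cc(C#N)c1O`, gives in an assay on isolated protein for inhibition of solute carrier family 22 member 12 (Homo sapiens), tested at 3 uM (a lower number here means less inhibition, a higher number more inhibition at the concentration tested (going by the name of the read-out)), a value of 54%. Compound 2, `N#Cc1cc(C(=O)N2CC=CC2)cc(C(F)(F)F)c1O`, gives in this assay a value of 83%. Within the data shown here, the one step known so far, trifluoromethyl in place of ethyl on an aromatic carbon, raised the number a number 29 percentage points higher from compound 1 to compound 2 (beyond the scatter). Compound 1 therefore stands lowest of the two numbers measured, and its nearest neighbour is compound 2.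

Compound 3, `N#Cc1cc(C(=O)N2CC=CC2)cc(Cl)c1O`, is not yet measured. Relative to compound 1 it differs in one place: chloro in place of ethyl on an aromatic carbon. Among the measured compounds shown here, the only step that bears on it is the one from compound 1 to compound 2, which also replaced ethyl on this aromatic carbon, ortho to the hydroxy group, and gave a modest rise beyond the scatter. Chloro is a different group from trifluoromethyl, so the step is expected to point the same way but to be smaller: for compound 3 the expected step in this assay is a number 14 percentage points higher from compound 1 to compound 3 (beyond the scatter). The estimate for compound 3 is 68%, with a range from 50% to 85%.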

Compound 3, a percentage reported as inhibition, at one concentration (the size of the read-out at that concentration, not a potency): 66%
The estimate for compound 3 lay 2 percentage points above the measured number; the measured number falls inside the stated range.
By their numbers in this assay, from the lowest: compound 1; then compound 3; then compound 2.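

At the aromatic carbon ortho to a hydroxy group and meta to a cyano group, a second replacement of ethyl now also raises the number in this assay (a number 12 percentage points higher from compound 1 to compound 3 (beyond the scatter)), so the rise seen with trifluoromethyl is not confined to that one group, although only these two replacements are shown. The identity of the entering group also counts, as chloro in place of trifluoromethyl lowers the number (a number 17 percentage points lower from compound 2 to compound 3 (beyond the scatter)), which places chloro between ethyl and trifluoromethyl in this set of three compounds, with each gap beyond the scatter. No measurement at hand bears on what lies behind this order, and the three values alone give no reason for it.

Going by these compounds, whether a fluoro, a methoxy or an amine on this same aromatic carbon would fall within the order of these three groups remains open. Also open, on these data alone, is whether the same order would hold if the cyano group were replaced by a carboxylic acid, since all three compounds share the rest of the core.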